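The source may hold more compounds than are shown below. What is called first, only, known or untested is meant among the compounds shown, and "the series" means these compounds.

Compound 2 `COc1ccc(Cn2c(-c3ccccc3)c(-c3ccccc3)c3c(=N)n([C@H]4CC[C@H](O)CC4)cnc32)cc1` was examined in an ADME assay for permeability, using PAMPA, with a stated time of 30 min, at pH 7.4; on this read-out higher numbers stand for higher permeability and lower numbers for lower permeability. In this assay compound 2 gives > 1000 10^-6 cm/s, which is a limit of the assay rather than a number. Compound 1 `N=c1c2c(-c3ccccc3)c(-c3ccccc3)n(CC3CCCCC3)c2ncn1CCCO`, which carries a 3-hydroxypropyl on the same ring nitrogen, also sits at a limit in this assay, giving > 1000 10^-6 cm/s. Both measured values therefore rest at the limit of > 1000 10^-6 cm/s in this assay, at which 2 of the 2 values shown sit. Compound 3 `COc1ccc(Cn2c(-c3ccccc3)c(-c3ccccc3)c3c(=N)n(CCCO)cnc32)cc1` has not yet been measured; it differs from compound 2 in one place: 3-hydroxypropyl in place of 4-hydroxycyclohexyl on an aromatic nitrogen. Going by the values given here, no step between measured compounds covers this change, so its size cannot be read from the data. Compound 3 is expected to give 1000 10^-6 cm/s in this assay, within 500 10^-6 cm/s to 1500 10^-6 cm/s, and most likely to reach the limit again. The expected step of a number no higher from compound 2 to compound 3 (the limit leaves the size open) is none beyond the usual scatter, since compound 1 with the same group already sits at the limit shown as the limit of > 1000 10^-6 cm/s in this assay, at which 2 of the 2 values shown sit.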

Compound 3, apparent permeability: > 1000 10^-6 cm/s
Compound 3: a limit, no number (the forecaster's own chance of this, stated with the estimate: 85%); the middle value lies on the limit itself.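

The steps from compound 2 to compound 3 and from compound 1 to compound 3 cannot be read, because each value is a limit and not a number: the limit of > 1000 10^-6 cm/s in this assay, at which 3 of the 3 values shown sit.

The compounds shown leave open how far compound 1, compound 2 and compound 3 differ in this assay, and whether their groups matter there at all.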